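A few compounds are considered here, and "the series" means these few. Any claim that something is new, unique, unknown or untested is made for them only; others in the source may bear on it.

Compound 2 `CC(C)C(CC(=O)OCC1(CO)C/C(=C\c2cccc(O)c2)C(=O)O1)C(C)C` gives 2.46 nM in an assay for displacement of a labelled ligand from protein kinase C delta type (Mus musculus), with a stated time of 30 min, in the presence of a further agent that is not named here (a lower number here means tighter binding, a higher number weaker binding), the lowest of the two numbers measured. Within the data shown here, its neighbour compound 1 `CC(C)C(CC(=O)OCC1(CO)C/C(=C\c2cccc(C(=O)O)c2)C(=O)O1)C(C)C` gives 2100 nM, and the only measured step, an 850-fold lower number from compound 1 to compound 2 (2.93 log units; beyond the scatter), swaps one group for another. Compound 3 `CC(C)C(CC(=O)OCC1(CO)C/C(=C\c2ccc(O)cc2)C(=O)O1)C(C)C` differs from compound 2 only in 4-hydroxyphenyl in place of 3-hydroxyphenyl on a double-bonded chain carbon bound to a double-bonded ring carbon. Among the measured compounds shown here, no measured step moves a group from one ring position to another, so the earlier large step gives little guidance here. A modest weakening of binding, a 2.4-fold higher number from compound 2 to compound 3 (0.39 log units; beyond the scatter), is expected, with wide uncertainty. Compound 3 is therefore estimated at 6 nM, between 1.5 nM and 40 nM.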

Compound 3, dissociation constant: 2.95 nM
The estimate for compound 3 lay 2.0-fold (0.31 log units) above the measured number; the range from low to high includes it.
By their numbers in this assay, from the lowest: compounds 2 and 3 (each within the scatter of the next); then compound 1.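

In this assay, 4-hydroxyphenyl in place of 3-hydroxyphenyl gives a 1.2-fold higher number from compound 2 to compound 3 (0.08 log units; within the scatter), so at this place the two hydroxyphenyl groups cannot be told apart. The large gain over the carboxy-bearing compound also holds for the second hydroxyphenyl group, with a 710-fold lower number from compound 1 to compound 3 (2.85 log units; beyond the scatter). Tight binding here therefore does not depend on which of these two ring positions carries the hydroxy group. On these data alone, how an amine or a methoxy group on the same ring would compare remains open. No data shown here explain the gap between the hydroxy compounds and compound 1.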